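Cysteinyl leukotriene receptor 2 antagonists: tetrafluorophenyl isomer note

This account rests on a few compounds, and the source may have more. Where it says the series, first, only, none or still open, it means among the compounds named here.

Measured compounds:
compound 1 `Cc1c(CCCC(=O)O)c2cccc(/C=C/c3ccc(OCCCCc4c(F)c(F)cc(F)c4F)cc3)c2n1CC(=O)O` — 3.7 nM
compound 2 `Cc1c(Cl)cccc1CCCCOc1ccc(C#Cc2cccc3c(CCC(=O)O)c(C)n(CCCCC(=O)O)c23)cc1` — 60 nM

In a functional assay on HEK293 cells for antagonist activity at cysteinyl leukotriene receptor 2 (Homo sapiens), read by fluorescence and calcium flux, with stated times of 30 min and 1 h (on this read-out higher numbers stand for weaker inhibition and lower numbers for stronger inhibition), compound 1 gives 3.7 nM, the lower of the two numbers. Compound 2 gives 60 nM in this assay, a higher number, and the gap between the two lies beyond the scatter. The two compounds differ in several places at once, so their values say nothing about any single change.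

Compound 3 `Cc1c(CCCC(=O)O)c2cccc(/C=C/c3ccc(OCCCCc4cc(F)c(F)c(F)c4F)cc3)c2n1CC(=O)O` differs from compound 1 in one place only: 2,3,4,5-tetrafluorophenyl in place of 2,3,5,6-tetrafluorophenyl on a saturated chain carbon, four bonds along the chain from an oxygen on an aromatic ring. Within the data shown here, no measured pair in this set isolates a change of this kind, so nothing here shows what moving one fluorine around the ring does. With the same atoms rearranged on a distant ring, the step is expected to be small, at most a slight rise in the number and plausibly none beyond the scatter. Compound 3 is accordingly estimated at 5 nM, within 2 nM to 15 nM, a step of a 1.4-fold higher number from compound 1 to compound 3 (0.13 log units; within the scatter) in this assay.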

Compound 3, half-maximal inhibitory concentration: 1.5 nM
Compound 3: the middle estimate sits 3.3-fold (0.52 log units) above what was measured; the measured number lies below the stated range.
By their numbers in this assay, from the lowest: compound 3; then compound 1; then compound 2.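

In this assay, among these compounds, 2,3,4,5-tetrafluorophenyl in place of 2,3,5,6-tetrafluorophenyl gives a 2.5-fold lower number from compound 1 to compound 3 (0.39 log units; beyond the scatter), the first single-place comparison. The number at this position, on a saturated chain carbon, four bonds along the chain from an oxygen on an aromatic ring, therefore responds to a rearrangement of the same atoms alone, with the step modest but beyond the scatter. Nothing at hand explains the step.

Still open, as far as these compounds go, is whether the lower number is particular to this fluorine arrangement, which pentafluorophenyl or 2,3,4-trifluorophenyl on the same chain would help settle. Also open, from the compounds shown here alone, is whether the same change would give a similar step on the core of compound 2, which differs from compound 1 in several places.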